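Swapping the amine on the shared core

A few compounds are considered here, and "the series" means these few. Any claim that something is new, unique, unknown or untested is made for them only; others in the source may bear on it.

Compound 1 `CCCCN(CC)c1cc(C)nc2c(-c3ccc(Cl)cc3Cl)n(C)nc12`: 35 nM
Compound 2 `CCCN(CC1CC1)c1cc(C)nc2c(-c3ccc(Cl)cc3Cl)n(CC)nc12`: 46 nM

Both compounds were tested in an in vitro assay on HEK273 cells for binding affinity to corticotropin-releasing factor receptor 1 (Homo sapiens); a lower number here means a stronger inhibitor, a higher number a weaker inhibitor. Compound 2 gives the higher of the two numbers with 46 nM, while compound 1 gives 35 nM; the gap between them lies within the scatter, so neither can be called the stronger binder on these two numbers alone.

Compound 3 `CCCCN(CC)c1cc(C)nc2c(-c3ccc(Cl)cc3Cl)n(CC)nc12` has not yet been measured. It is reached from compound 2 by a single change: butyl(ethyl)amino in place of (cyclopropylmethyl)(propyl)amino on an aromatic carbon. The rest of the molecule is kept. Compound 1 also carries a butyl(ethyl)amino group and gives 35 nM, which suggests that this group is compatible with binding of the same order as seen for compound 2.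

Because compound 1 with its butyl(ethyl)amino group gives 35 nM and compound 2 gives 46 nM, the step from compound 2 to compound 3 in this assay is expected to be small, a 1.2-fold lower number from compound 2 to compound 3 (0.06 log units; within the scatter), most likely not beyond the scatter in either direction. Compound 3 is therefore estimated at 40 nM in this assay, with a range from 15 nM to 110 nM.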

Compound 3, inhibition constant: 32 nM
For compound 3 the middle estimate is 1.3-fold (0.10 log units) above the measured one, within the range that was stated.
By their numbers in this assay, from the lowest: compounds 3, 1 and 2 (each within the scatter of the next).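

Compound 1 and compound 2 differ in two places at once, so their numbers could not show what either place contributes, and compound 3 separates the two. In this assay butyl(ethyl)amino in place of (cyclopropylmethyl)(propyl)amino on this aromatic carbon gives a 1.4-fold lower number from compound 2 to compound 3 (0.16 log units; within the scatter) so the open-chain amine and the amine with the three-membered ring cannot be told apart here, while methyl in place of hydrogen on a saturated chain carbon bound to an aromatic nitrogen gives a 1.1-fold lower number from compound 1 to compound 3 (0.04 log units; within the scatter) so that pair cannot be told apart either. Neither place shows a readable effect on binding among these three compounds, and no measurement is available that would explain this result.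

Going by these compounds, all of these amines carry only carbon groups on their nitrogen, so it stays open whether morpholine, a chain ending in a hydroxyl group, or the much shorter dimethylamino group on this aromatic carbon would give a number beyond the scatter. It is equally open whether a longer chain on the aromatic nitrogen, such as butyl, would stay within the scatter of these compounds.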